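Removing the isopropyl: from compound 1 to compound 3

This account rests on a few compounds, and the source may have more. Where it says the series, first, only, none or still open, it means among the compounds named here.

Within the data shown here, compound 1 `CC(C)[C@H](NC(=O)c1ccc(C(=O)Nc2ccc3c(c2)C(C)(C)CCC3(C)C)cc1)C(=O)OCc1c(-c2ccccc2)no[n+]1[O-]` is the only compound with a numerical result: in a functional assay on K562 cells (Homo sapiens) for antiproliferative activity, read by MTT assay, with a stated time of 48 h (a higher number here means a weaker inhibitor, a lower number a stronger inhibitor), compound 1 gives 192000 nM. Compound 2 `CC1(C)CCC(C)(C)c2cc(NC(=O)c3ccc(C(=O)OCCCCCCOC(=O)c4ccc(OCc5c(-c6ccccc6)no[n+]5[O-])cc4)cc3)ccc21` reaches only a limit of the assay, and in this assay compound 2 gives > 1000000 nM. Among the measured compounds shown here, the limit of > 1000000 nM in this assay, at which 1 of the 2 values shown sits, covers one of the two values, so compound 1 stands as the sole measured number.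

Compound 3 `CC1(C)CCC(C)(C)c2cc(NC(=O)c3ccc(C(=O)NCC(=O)OCc4c(-c5ccccc5)no[n+]4[O-])cc3)ccc21` differs from compound 1 by hydrogen in place of isopropyl on a saturated chain carbon bound to an amide-type nitrogen and a carbonyl carbon. No measured step of this kind exists among these compounds, so the size of the step in this assay can only be judged cautiously; a shift beyond the usual scatter is not expected in either direction. The step of a 1.1-fold higher number from compound 1 to compound 3 (0.06 log units; within the scatter) is expected to stay within that scatter. In this assay compound 3 is estimated at 220000 nM, with a range from 70000 nM to 700000 nM.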

Compound 3, half-maximal inhibitory concentration: 7120 nM
Compound 3: middle estimate off by 31-fold (1.49 log units), on the high side, and the stated range ends above it.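

In this assay, putting hydrogen in place of isopropyl on the saturated chain carbon bound to an amide-type nitrogen and a carbonyl carbon gives a 27-fold lower number from compound 1 to compound 3 (1.43 log units; beyond the scatter), the only measured step among these compounds. It shows that this carbon is not a silent position: what it carries can move the read-out well beyond the usual scatter. Of this pair, compound 3, without the isopropyl, is the stronger inhibitor, but nothing shown bears on why the number falls so far.

As far as these compounds go, whether a single methyl on this carbon would give a number nearer that of compound 1 or that of compound 3 remains open. So does how an aminomethyl or a carboxymethyl group at the same place would behave in this assay.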